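Side-chain exchange on compound 3: carbamoyl to methylsulfanyl

A few compounds are considered here, and "the series" means these few. Any claim that something is new, unique, unknown or untested is made for them only; others in the source may bear on it.

Measured so far in a functional assay on the whole organism with Mus musculus as the target, with a stated time of 90 min, at a dose of 25 umol/kg by the oral route; a higher number here means a stronger effect of the compound at the dose given, a lower number a weaker effect:
compound 1 `O=C(O)CN(c1nc(Cl)nc2c1ncn2C1CCCCO1)C1CC1` gives 8.22%
compound 2 `C[C@H](NC(=O)CN(c1nc(Cl)nc2c1ncn2C1CCCCO1)C1CC1)C(=O)OCc1ccccc1` gives 32.1%
compound 3 `NC(=O)CC[C@H](NC(=O)CN(c1nc(Cl)nc2c1ncn2C1CCCCO1)C1CC1)C(=O)OCc1ccccc1` gives 37.8%

Compound 3 holds the highest of the three numbers in this assay. Its gap to compound 2 lies within the scatter, so the two cannot be ordered against each other; only the gap to compound 1 is beyond the scatter. Within the data shown here, the single step between measured compounds that differ in one place, a number 5.7 percentage points higher from compound 2 to compound 3 (within the scatter), is itself within the scatter.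

Compound 4 `CSCC[C@H](NC(=O)CN(c1nc(Cl)nc2c1ncn2C1CCCCO1)C1CC1)C(=O)OCc1ccccc1` is the unmeasured member of the series. It differs from compound 3 in one place: methylsulfanyl in place of carbamoyl on a saturated chain carbon, three bonds along the chain from an amide-type nitrogen and a carbonyl carbon. Among the measured compounds shown here, no measured pair carries this exchange, and the only step that has been measured at all, a number 5.7 percentage points higher from compound 2 to compound 3 (within the scatter), did not leave the scatter. The measured numbers give no ground to expect a step beyond the scatter in either direction; the expected step is a number 2.8 percentage points lower from compound 3 to compound 4 (within the scatter), a change of no more than the usual spread. Compound 4 is expected to give 35% in this assay, with a range from 22% to 48%.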

Compound 4, a percentage reported as activity, at one dose (the size of the read-out at that dose, not a potency): 42.7%
The estimate for compound 4 lay 7.7 percentage points below the measured number; the range from low to high includes it.
By their numbers in this assay, from the lowest: compound 1; then compounds 2, 3 and 4 (each within the scatter of the next, the first and the last beyond it).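

In this assay the exchange of carbamoyl for methylsulfanyl gives a number 4.9 percentage points higher from compound 3 to compound 4 (within the scatter) and so does not separate the two side chains, which shows that the hydrogen-bond donor of carbamoyl is not required to keep the read-out at this level at the dose given. Among these compounds, the step of a number 10.6 percentage points higher from compound 2 to compound 4 (beyond the scatter) is the first at this saturated chain carbon to leave the scatter, though only modestly, and it shows that a substituent here can raise the number over hydrogen, whereas the earlier step with carbamoylmethyl, a number 5.7 percentage points higher from compound 2 to compound 3 (within the scatter), could not show this. Compound 3 stays within the scatter of both compound 2 and compound 4, so the series supports no ranking of carbamoylmethyl against either neighbour, and nothing in hand gives a reason for either step.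

Still open, on these data alone, is whether the sulfur of (methylsulfanyl)methyl matters, or whether a plain propyl chain would serve as well at this chain carbon. Also open, as far as these compounds go, is how a side chain ending in an amine or a carboxylic acid would read out here, and whether a longer chain such as 3-(methylsulfanyl)propyl would move the number further from that of compound 2.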